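Swapping a Cyano for an Ethoxycarbonyl on a Weak Antagonist

The source may report more compounds than this note shows. Statements on the series, on what has been measured and on what is new or still open speak of the compounds shown alone.

Compound 1 `Cc1cc(NNC(=O)Nc2cc(Cl)nc(Cl)c2)ncc1C#N` was tested in a functional assay on CHO cells for antagonist activity at sphingosine 1-phosphate receptor 2 (Homo sapiens), read by fluorescence and calcium flux, with a stated time of 3 min (on this read-out higher numbers stand for weaker inhibition and lower numbers for stronger inhibition), where compound 1 gives 6000 nM. Its isomer, compound 2 `Cc1cc(C#N)nc(NNC(=O)Nc2cc(Cl)nc(Cl)c2)c1`, reached only the ceiling of the assay, so the result for compound 2, > 6600 nM, is a limit and not a number (the limit of > 6600 nM in this assay, at which 1 of the 2 values shown sits). Compound 3 `CCOC(=O)c1cc(C)cc(NNC(=O)Nc2cc(Cl)nc(Cl)c2)n1` differs from compound 2 by ethoxycarbonyl in place of cyano on an aromatic carbon. Within the data shown here, no measured step of this kind exists here, so the expected step is a step that the limit leaves unreadable from compound 2 to compound 3, a size within the usual scatter and in no clear direction. Compound 3 is therefore estimated at 8000 nM, between 2500 nM and 30000 nM, with a limit again likely.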

Compound 3, half-maximal inhibitory concentration: 760 nM
The estimate for compound 3 lay 11-fold (1.02 log units) above the measured number, outside the stated range (below it).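

At this position, on an aromatic carbon next to the ring nitrogen, the group is not a silent spectator: ethoxycarbonyl in place of cyano gives an at least 8.6-fold lower number from compound 2 to compound 3 (0.93 log units; beyond the scatter) in this assay. On these data alone, the true size of this step stays unknown, because compound 2 sits at a limit and not at a number: the limit of > 6600 nM in this assay, at which 1 of the 3 values shown sits. The compounds shown leave open whether the whole ethoxycarbonyl group is needed, and whether a carboxylic acid, an amide or a longer chain at the same place would go the same way.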